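The compounds below may be only part of what the source reports. "The series", "measured", "known", "first", "only" and "open" are said of these compounds alone.

Measured so far:
compound 1 `COc1cccc(F)c1-c1cccc2nc(N)oc12` — 2800 nM
compound 2 `COc1cccc(F)c1-c1cccc2nc(Nc3cccc(S(N)(=O)=O)c3)oc12` — 340 nM
compound 3 `COc1cc(Nc2nc3cccc(-c4ccccc4OC(F)(F)F)c3o2)cc(OC)c1OC` — 4000 nM

All three were tested in an assay on isolated protein for inhibition of ribosomal protein S6 kinase alpha-2 (Homo sapiens), with a stated time of 150 min; a higher number here means a weaker inhibitor, a lower number a stronger inhibitor. Compound 3 carries the highest of the three numbers, but the gap to compound 1 lies within the usual scatter of repeated measurements, so the two cannot be told apart; only the gap to compound 2 lies beyond it, and compound 2 gives the clearly stronger inhibition in this assay.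

Compound 4 `COc1cc(Nc2nc3cccc(-c4c(F)cccc4OC(C)C)c3o2)cc(OC)c1OC` keeps the shared core of compound 3 and the same trimethoxy-bearing amine, and changes only the ring that hangs from the core: a group of 11 heavy atoms (9 carbon, 1 oxygen, 1 fluorine; one six-membered aromatic ring of carbon only) in place of a group of 11 heavy atoms (7 carbon, 1 oxygen, 3 fluorine; one six-membered aromatic ring of carbon only), on an aromatic carbon. Among the compounds with values here, nothing among the measured compounds tracks this exact swap, so there is no measured step to lean on. Since the new group has the same size and the same count of donors and acceptors as the one it replaces, the expected step from compound 3 to compound 4 is small, a 1.6-fold lower number from compound 3 to compound 4 (0.20 log units; within the scatter), and may well stay within the scatter, with a slight lean toward a lower number. On that basis compound 4 is expected to give about 2500 nM in this assay, with a plausible range from 800 nM to 8000 nM.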

Compound 4, half-maximal inhibitory concentration: 970 nM
Beside the measured number, compound 4's estimate is 2.6-fold (0.41 log units) above it, within the range that was stated.
By their numbers in this assay, from the lowest: compound 2; then compound 4; then compounds 1 and 3 (each within the scatter of the next).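

Within the data shown here, with the shared core and the trimethoxy-bearing amine held fixed, exchanging the 2-(trifluoromethoxy)phenyl group for the entering group gives a 4.1-fold lower number from compound 3 to compound 4 (0.62 log units; beyond the scatter) in this assay, the first measured change in a single place in this set, and it shows that the ring hanging from the core can shift the number beyond the scatter. The two groups have the same count of heavy atoms, donors and acceptors and neither carries a net charge, so these counts alone do not settle the number at this position. No measurement shown here bears on why the exchange gives this step.

The exchange alters more than one feature of the ring at once, so the compounds shown cannot say how much of the step belongs to the loss of the trifluoromethoxy group, and how much to the fluorine or the other ether group that enter. Going by these compounds, it also remains open whether a plain phenyl ring, or a ring carrying a carboxylic acid or an amine at this position, would give a lower or higher number, and whether the same exchange gives a similar step on a different amine.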